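The source may hold more compounds than are shown below. What is called first, only, known or untested is meant among the compounds shown, and "the series" means these compounds.

For the measured compounds named here, compound 3 `Clc1ccc2c(N/N=C/c3ccco3)ccnc2c1` gives 19.9 uM in a functional assay on KB cells (Homo sapiens) for cytotoxicity (a higher number here means that more compound is needed for the effect, a lower number that less compound is needed), which places it second highest of the three numbers known so far. Its nearest neighbour is compound 1 `Clc1ccc2c(N/N=C/c3cccs3)ccnc2c1`, which gives 10.4 uM; the step of a 1.9-fold higher number from compound 1 to compound 3 (0.28 log units; within the scatter) lies within the scatter. The furthest is compound 2 `Cc1noc(C)c1/C=N/Nc1ccnc2cc(Cl)ccc12`, which gives 171 uM; the step of an 8.6-fold lower number from compound 2 to compound 3 (0.93 log units; beyond the scatter) is beyond the scatter, as is a 16-fold higher number from compound 1 to compound 2 (1.22 log units; beyond the scatter).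

Compound 4 `Clc1ccc2c(N/N=C/c3cnc[nH]3)ccnc2c1` differs from compound 3 by 1H-imidazol-5-yl in place of furan-2-yl on a carbon with a double bond to nitrogen. Going by the values given here, no measured step contains 1H-imidazol-5-yl, so the expectation rests on the other swaps of the ring on the carbon with a double bond to nitrogen. The step of a 1.9-fold higher number from compound 1 to compound 3 (0.28 log units; within the scatter) shows that exchanging one five-membered aromatic ring with 1 hetero atom for another leaves the number within the scatter, whereas an 8.6-fold lower number from compound 2 to compound 3 (0.93 log units; beyond the scatter) and a 16-fold higher number from compound 1 to compound 2 (1.22 log units; beyond the scatter) show that the ring with 2 hetero atoms, 3,5-dimethyl-1,2-oxazol-4-yl, gave a clearly higher number. Among the compounds with values here, the entering group is again a five-membered aromatic ring with 2 hetero atoms and brings 1 hydrogen-bond donor, which none of the measured rings has. One therefore expects a modest rise beyond the scatter, smaller than that seen for compound 2. Compound 4 is expected to give 45 uM, within 14 uM to 150 uM. The expected step is a 2.3-fold higher number from compound 3 to compound 4 (0.35 log units; beyond the scatter).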

Compound 4, concentration for half-maximal effect: 29.1 uM
Compound 4: middle estimate off by 1.5-fold (0.19 log units), on the high side; the range from low to high includes it.
By their numbers in this assay, from the lowest: compounds 1, 3 and 4 (each within the scatter of the next, the first and the last beyond it); then compound 2.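

In this assay, the step (a 1.5-fold higher number from compound 3 to compound 4 (0.17 log units; within the scatter)) shows that a five-membered aromatic ring with 2 hetero atoms on the carbon with a double bond to nitrogen need not stand apart from furan-2-yl, and the step (a 5.9-fold lower number from compound 2 to compound 4 (0.77 log units; beyond the scatter)) separates 1H-imidazol-5-yl clearly from 3,5-dimethyl-1,2-oxazol-4-yl, so the count of hetero atoms alone does not account for the number of compound 2. The hydrogen-bond donor of 1H-imidazol-5-yl, new at this position, does not set compound 4 apart from compound 3, yet the step (a 2.8-fold higher number from compound 1 to compound 4 (0.45 log units; beyond the scatter)) is beyond the scatter, so compound 4 is separated from compound 1 although compound 3 lies within the scatter of both. No measurement among those available explains these differences.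

The compounds shown leave open whether the high number of compound 2 goes with the methyl groups of 3,5-dimethyl-1,2-oxazol-4-yl or with the ring that carries them. They also leave open how a six-membered ring such as phenyl or pyridinyl, or a ring bearing an amine or a carboxylic acid, would read on this carbon.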